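Trifluoromethyl on the Benzyl Ring of a Urea Analogue

This account rests on a few compounds, and the source may have more. Where it says the series, first, only, none or still open, it means among the compounds named here.

Compound 1 `Cc1ccc(NC(=S)NC(=O)c2ccc(OCc3ccc(Cl)cc3Cl)cc2)cc1-c1nc2ccccc2[nH]1`: 5300 nM
Compound 2 `Cc1ccc(NC(=O)NC(=O)c2ccc(OCc3ccccc3)cc2)cc1-c1nc2ccccc2[nH]1`: 35100 nM

In a functional assay on MNK45 cells (Homo sapiens) for inhibition, read by MTT assay, with a stated time of 48 h (on this read-out lower numbers stand for stronger inhibition and higher numbers for weaker inhibition), compound 2 gives 35100 nM, the highest of the two numbers shown. Its nearest neighbour, compound 1, gives 5300 nM, a gap beyond the scatter. Compound 3 `Cc1ccc(NC(=O)NC(=O)c2ccc(OCc3ccc(C(F)(F)F)cc3)cc2)cc1-c1nc2ccccc2[nH]1` differs from compound 2 by trifluoromethyl in place of hydrogen on an aromatic carbon, on an aromatic carbon of a six-membered aromatic ring of carbon only, para to a large group. Among the measured compounds shown here, no measured pair isolates this change, so the direction rests on little. Compound 3 is expected to move modestly toward lower numbers in this assay, a step of a 1.8-fold lower number from compound 2 to compound 3 (0.24 log units; within the scatter), giving an estimate of 20000 nM with a range from 6000 nM to 60000 nM.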

Compound 3, half-maximal inhibitory concentration: 16800 nM
Compound 3: middle estimate off by 1.2-fold (0.08 log units), on the high side; low and high end bracket the measured number.
By their numbers in this assay, from the lowest: compound 1; then compound 3; then compound 2.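

In this assay trifluoromethyl in place of hydrogen on the benzyl ring, para to a large group, gives a 2.1-fold lower number from compound 2 to compound 3 (0.32 log units; beyond the scatter) as the first step isolated at this position. This position therefore takes a group of four heavy atoms with no loss of inhibition, and the step points modestly toward stronger inhibition. Nothing available explains this step. As far as these compounds go, whether a methoxy group, a nitrile or a single chlorine at the same place would move the number likewise stays open, as does whether trifluoromethyl has the same effect on a thiourea such as compound 1.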